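This account rests on a few compounds, and the source may have more. Where it says the series, first, only, none or still open, it means among the compounds named here.

Among the measured compounds shown here, compound 2 `O[C@H]1Cc2ccccc2C1NC1CCN(CCCc2c[nH]c3ccc(-n4cnnc4)cc23)CC1` gives the higher of the two numbers measured so far in an assay on CHO cells for displacement of a labelled ligand from 5-hydroxytryptamine receptor 1B (Homo sapiens); a lower number here means a stronger inhibitor, a higher number a weaker inhibitor: compound 2 gives 300 nM, whereas compound 1 `O=S(=O)(NCC1CCN(CCCc2c[nH]c3ccc(-n4cnnc4)cc23)CC1)c1ccccc1` gives 60 nM. For the measured compounds named here, the single step known between them, a 5.0-fold higher number from compound 1 to compound 2 (0.70 log units; beyond the scatter), shows that exchanging the substituent on the saturated ring carbon of the shared core moves the number by a modest amount beyond the scatter.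

Compound 3 `CC(=O)Nc1ccc(CNC2CCN(CCCc3c[nH]c4ccc(-n5cnnc5)cc34)CC2)cc1` is reached from compound 2 by 4-acetamidobenzyl in place of 2-hydroxy-2,3-dihydro-1H-inden-1-yl on an amine nitrogen. Going by the values given here, no measured step involves a benzyl group of this kind on that amine nitrogen, so the expectation rests only on the lesson of the step from compound 1 to compound 2: a substituent with an aromatic ring attached through a short link on the amine side gave the lower number, and the 2-hydroxy-2,3-dihydro-1H-inden-1-yl group gave the higher one. Returning to an aromatic ring attached by a single carbon is therefore expected to bring the number back toward that of compound 1, though with real uncertainty, so in this assay compound 3 is estimated at 110 nM, with a range from 30 nM to 400 nM, which means an expected step of a 2.7-fold lower number from compound 2 to compound 3 (0.44 log units; beyond the scatter).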

Compound 3, half-maximal inhibitory concentration: 45 nM
The estimate for compound 3 lay 2.4-fold (0.39 log units) above the measured number, within the range that was stated.
By their numbers in this assay, from the lowest: compounds 3 and 1 (each within the scatter of the next); then compound 2.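

In this assay, among the compounds shown here, this step gives the first measured change between two substituents on the amine nitrogen whose other neighbour is a saturated ring carbon: 4-acetamidobenzyl in place of 2-hydroxy-2,3-dihydro-1H-inden-1-yl gives a 6.7-fold lower number from compound 2 to compound 3 (0.82 log units; beyond the scatter) for a swap of nearly equal heavy-atom size. The amine link itself therefore does not fix the number at the level of compound 2, as compound 3 gives 45 nM and compound 1 gives 60 nM, two values within the scatter of each other. Nothing available explains the step, and the change alters several things at once, removing a five-membered non-aromatic ring and a defined stereocentre and bringing in a double bond outside aromatic rings.

The compounds shown leave open how much of the step belongs to the acetamido part of the 4-acetamidobenzyl group, which a plain benzyl or a 4-methoxybenzyl on the same amine nitrogen would help to separate. They also leave open whether the hydroxyl of the leaving group contributes to the number of compound 2, a question that an unsubstituted indanyl group at this place would address.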